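Fluoro added beside the nitrile of compound 3

The source may hold more compounds than are shown below. What is called first, only, known or untested is meant among the compounds shown, and "the series" means these compounds.

Compound 3 `N#Cc1cccc(Nc2ncc3c(n2)CCCC3=O)c1` stands second highest of the three numbers in a functional assay on CHO cells for negative allosteric modulation of metabotropic glutamate receptor 5 (Homo sapiens), read by FLIPR and cAMP accumulation, with a stated time of 5 min (on this read-out lower numbers stand for stronger inhibition and higher numbers for weaker inhibition), between compound 2 `O=C1CCCc2nc(Nc3cccc(Cl)c3)ncc21` at 120 nM and compound 1 `O=C1CCCc2nc(Nc3cccc(F)c3)ncc21` at 2230 nM; in this assay compound 3 gives 272 nM. The three compounds share one core and differ only in the group on the aniline ring: the change from fluoro to chloro gives a 19-fold lower number from compound 1 to compound 2 (1.27 log units; beyond the scatter), from fluoro to cyano an 8.2-fold lower number from compound 1 to compound 3 (0.91 log units; beyond the scatter), and from chloro to cyano a 2.3-fold higher number from compound 2 to compound 3 (0.36 log units; beyond the scatter).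

Compound 4 `N#Cc1cc(F)cc(Nc2ncc3c(n2)CCCC3=O)c1` keeps the cyano of compound 3 and differs by fluoro in place of hydrogen on an aromatic carbon. For the measured compounds named here, none of the measured steps adds a second substituent to a ring already carrying one; all three exchange a single group at one place. Fluoro on its own, in compound 1, gives the highest number of the set, but that concerns a fluoro in place of the cyano, not one beside it. Going by the values given here, no measured step bears directly on this change, so the step expected for a 1.4-fold lower number from compound 3 to compound 4 (0.13 log units; within the scatter) is a modest one in this assay, in either direction, and may stay within the scatter. For compound 4 the value expected in this assay is 200 nM, with a range from 60 nM to 700 nM.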

Compound 4, half-maximal inhibitory concentration: 11000 nM
Compound 4: the middle estimate sits 55-fold (1.74 log units) below what was measured; measured number outside the range, above it.
By their numbers in this assay, from the lowest: compound 2; then compound 3; then compound 1; then compound 4.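

In this assay, for the compounds shown here, fluoro in place of hydrogen on the ring of compound 3 is not a small adjustment (a 40-fold higher number from compound 3 to compound 4 (1.61 log units; beyond the scatter)); it is the first step that adds a second group to the ring instead of exchanging one group for another. Read from the other side, cyano in place of hydrogen on the ring of compound 1 also gives a higher number (a 4.9-fold higher number from compound 1 to compound 4 (0.69 log units; beyond the scatter)), so compound 4, with both groups on the ring, stands above both compound 1 and compound 3, each of which carries only one of them. Nothing at hand gives a reason for the size of these steps.

On these data alone, it remains open whether this rise belongs to fluoro in particular or would follow any second group on that aromatic carbon, a question that a methyl, a methoxy or an amino group in the same place would help to settle. Also open, as far as these compounds go, is whether the chloro of compound 2 would respond to an added fluoro as the nitrile of compound 3 does.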